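Pyridazinyl piperazine ureas: isopropyl to trifluoromethoxy on the aryl ring

The source may report more compounds than this note shows. Statements on the series, on what has been measured and on what is new or still open speak of the compounds shown alone.

Measured so far:
compound 1, `Cc1ccc(N2CCN(C(=O)Nc3ccc(OC(F)(F)F)cc3)CC2)nn1`: > 10000 nM
compound 2, `Cc1cnnc(N2CCN(C(=O)Nc3ccc(C(C)C)cc3)CC2)c1`: 5020 nM

Among the compounds with values here, in an assay on HEK293 cells for inhibition of transient receptor potential cation channel subfamily V member 1 (Homo sapiens), read by FLIPR (a higher number here means a weaker inhibitor, a lower number a stronger inhibitor), compound 2 gives 5020 nM, the only numerical value in the set so far. For compound 1 this assay reports only a limit, > 10000 nM, with one of the two values sitting there (the limit of > 10000 nM in this assay, at which 1 of the 2 values shown sits). Compound 1 carries the trifluoromethoxy-substituted aryl urea on a different arrangement of the shared core, so its limit cannot be read as a step from compound 2.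

Compound 3, `Cc1cnnc(N2CCN(C(=O)Nc3ccc(OC(F)(F)F)cc3)CC2)c1`, keeps the core of compound 2 and changes the aryl substituent: trifluoromethoxy in place of isopropyl on an aromatic carbon, on an aromatic carbon of a six-membered carbon ring, para to a large group. Within the data shown here, no measured pair isolates this change, so the size of the step is open. The expectation is a step from compound 2 to compound 3 of a 1.6-fold higher number from compound 2 to compound 3 (0.20 log units; within the scatter), toward weaker inhibition or no change beyond the scatter. For compound 3 the estimated value in this assay is 8000 nM, within 3000 nM to 25000 nM, with a real chance that only a limit is reported.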

Compound 3, half-maximal inhibitory concentration: > 10000 nM
Compound 3 was reported as a limit; the forecaster's own chance of this, stated with the estimate: 45%; middle value at least 1.2-fold (0.09 log units) from the limit.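

In this assay, within the data shown here, trifluoromethoxy in place of isopropyl on an aromatic carbon, para to a large group, gives the first step that can be read at this position: an at least 1.9-fold higher number from compound 2 to compound 3 (0.29 log units; that floor lies within the scatter). Compound 3 is reported only as a limit, so the pair fixes a floor for the step and not its size, and the change shows no loss beyond the scatter, although a larger one is not excluded. The step from compound 1 to compound 3, 5-methylpyridazin-3-yl in place of 6-methylpyridazin-3-yl on an amine nitrogen in a ring, cannot be read, and the set now rests largely on one limit: the limit of > 10000 nM in this assay, at which 2 of the 3 values shown sit.

Still open, from the compounds shown here alone, is how far the true value of compound 3 lies from that of compound 2, and whether trifluoromethoxy costs anything at all. Also open, going by these compounds, is whether another group on the same aromatic carbon, such as tert-butyl, chlorine or trifluoromethyl, would give a number in this assay and show how this position responds to substitution.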